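The compounds below may be only part of what the source reports. "The series", "measured", "known", "first", "only" and "open" are said of these compounds alone.

Measured so far in the stomach inhibition assay:
- compound 1, `CC1=NN(C(C)CC(=N)S)C(=O)CC1`: 17.4%
- compound 2, `CC(CC(=N)S)N1N=C(c2ccccc2)CCC1=O`: 9.2%
- compound 3, `Cc1ccc(=O)n(CC(C)C(=N)S)n1`: 30.2%

In a functional assay on the whole organism (stomach) for inhibition, with Rattus norvegicus as the target, at a dose of 100 mg/kg by the intraduodenal route (on this read-out lower numbers stand for less inhibition and higher numbers for more inhibition at the one dose given (going by the name of the read-out)), compound 2 gives the lowest of the three numbers. Its nearest neighbour is compound 1, whose number is higher by a number 8.2 percentage points lower from compound 1 to compound 2 (within the scatter) read backwards; that step is within the scatter, so compounds 1 and 2 cannot be told apart on this read-out. Compound 3 stands furthest away, and its number lies beyond the scatter above that of compound 2.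

Compound 4, `N=C(S)CCCN1N=C(c2ccccc2)CCC1=O`, has the same atoms as compound 2 joined differently: a group of 6 heavy atoms (4 carbon, 1 nitrogen, 1 sulfur; no ring) in place of a group of 6 heavy atoms (4 carbon, 1 nitrogen, 1 sulfur; no ring), on an amide-type nitrogen in a ring. Going by the values given here, none of the measured steps rearranges atoms in this way; the only step, a number 8.2 percentage points lower from compound 1 to compound 2 (within the scatter), touches a different part of the shared core, so nothing measured bears directly on the change. The expectation is therefore a step of no more than the scatter, estimated as a number 2.8 percentage points higher from compound 2 to compound 4 (within the scatter). Compound 4 is expected to give 12% in this assay, with a range from 0% to 30%.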

Compound 4, a percentage reported as inhibition, in the whole organism at one dose (the size of the read-out at that dose, not a potency): 50.3%
Estimate against measurement, compound 4: 38.3 percentage points below, outside the stated range (above it).
By their numbers in this assay, from the lowest: compounds 2 and 1 (each within the scatter of the next); then compound 3; then compound 4.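

Going by this assay, the group on the amide-type nitrogen in a ring clearly matters: swapping one arrangement for the other gives a number 41.1 percentage points higher from compound 2 to compound 4 (beyond the scatter), whereas the one earlier step, phenyl in place of methyl, stayed within the scatter. Both groups hold the same 6 heavy atoms (4 carbon, 1 nitrogen, 1 sulfur), so at this position the way the atoms are joined can shift the number on its own, without any atom being added or removed. Nothing available explains why this rearrangement has such an effect.

Going by these compounds, it remains open whether the same rearrangement gives a similar step with methyl in place of phenyl. On these data alone, it is also open how a longer chain, or an amine or carboxylic acid, on this nitrogen would compare.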